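Fluoro for methoxy on a weak antiproliferative compound

The source may hold more compounds than are shown below. What is called first, only, known or untested is meant among the compounds shown, and "the series" means these compounds.

Compound 1 `COc1ccc(-c2nc3cccc(-c4cc(OC)c(OC)c(OC)c4)c3o2)cc1F` gives 2800 nM
Compound 2 `COc1ccc(-c2nc3c(-c4cc(OC)c(OC)c(OC)c4)cccc3o2)cc1OC` gives 8900 nM

Both numbers come from a functional assay on NCI-H460 cells (Homo sapiens) for antiproliferative activity, read by MTT assay, with a stated time of 48 h (a higher number here means a weaker inhibitor, a lower number a stronger inhibitor), and nothing else has been measured so far. Compound 2 holds the higher number of the two, which makes it the weaker inhibitor, and its gap to compound 1 lies beyond the usual scatter.

The next compound is compound 3 `COc1ccc(-c2nc3c(-c4cc(OC)c(OC)c(OC)c4)cccc3o2)cc1F` which keeps the core of compound 2 and carries fluoro in place of methoxy on an aromatic carbon. This turns 3,4-dimethoxyphenyl into 3-fluoro-4-methoxyphenyl. Going by the values given here, no measured pair shows this change alone, so its size is a judgement. Among the compounds with values here, compound 1 already carries 3-fluoro-4-methoxyphenyl on a differently arranged core and gives 2800 nM as the only guide. That suggests a modest move toward a lower number in this assay and perhaps not much beyond the scatter. The step expected is a 2.2-fold lower number from compound 2 to compound 3 (0.35 log units; beyond the scatter) as a rough estimate. Compound 3 is expected at 4000 nM with a likely range from 1300 nM to 12000 nM by this estimate.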

Compound 3, half-maximal inhibitory concentration: 19900 nM
Estimate against measurement, compound 3: 5.0-fold (0.70 log units) below, and the stated range ends below it.
By their numbers in this assay, from the lowest: compound 1; then compound 2; then compound 3.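

Within this assay the swap of methoxy for fluoro on this aromatic carbon gives a 2.2-fold higher number from compound 2 to compound 3 (0.35 log units; beyond the scatter) and so provides the first direct reading of this change: on this core, the compound with methoxy at this carbon is the stronger inhibitor of the pair, although the step is modest. It also changes how compound 1 reads, since the 3-fluoro-4-methoxyphenyl group does not by itself bring a low number: on the differently arranged core, compound 1 gives 2800 nM with this group, while compound 3 gives 19900 nM with the same group. Nothing available here accounts for the step.

Still open, going by these compounds, is whether the same change on the core of compound 1 would shift the number in the same direction and by a similar amount, so one pair cannot establish a general rule for this swap. On these data alone, it is also open how other groups on this aromatic carbon, such as chloro, hydroxyl or an amine, would compare with methoxy and fluoro on either core.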